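The compounds below may be only part of what the source reports. "The series", "measured", "known", "first", "only" and "open" are said of these compounds alone.

Compound 1 `COc1ccc(/C=C2\c3cc(OC)c(OC)c(OC)c3CC[C@@H]2O)cc1F`, compound 2 `COc1ccc(/C=C2\c3cc(OC)c(OC)c(OC)c3CC[C@@H]2O)cc1C#N` and compound 3 `COc1ccc(/C=C2\c3cc(OC)c(OC)c(OC)c3CC[C@H]2O)cc1F` have all been tested in a functional assay on SK-OV-3 cells (Homo sapiens) for inhibition, read by MTT assay; on this read-out higher numbers stand for weaker inhibition and lower numbers for stronger inhibition. In that test compound 1 gives 1 nM, compound 2 gives 20 nM and compound 3 gives 720 nM, the highest number of the three and so the weakest inhibition. Compound 4 `COc1ccc(/C=C2\c3cc(OC)c(OC)c(OC)c3CC[C@H]2O)cc1C#N` has not been measured yet. It differs from compound 3 in one place: cyano in place of fluoro on an aromatic carbon. In words, this is cyano in place of fluoro on an aromatic carbon, ortho to a methoxy group.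

Going by the values given here, two measured steps bear on this change. The same swap, made on the other configuration, gave a 20-fold higher number from compound 1 to compound 2 (1.30 log units; beyond the scatter), a large rise. Changing only the drawn stereocentre gave a 720-fold higher number from compound 1 to compound 3 (2.86 log units; beyond the scatter), an even larger rise, and that gap rests on (the fact that compounds 1 and 3 differ only in the configuration as drawn). The swap therefore has a single precedent, and it points toward a higher number in this assay. Compound 3 already stands at 720 nM, and one pair cannot show that a swap keeps its full size on the opposite configuration, so a somewhat smaller rise seems the safer expectation. The expected step is a 5.6-fold higher number from compound 3 to compound 4 (0.74 log units; beyond the scatter). For compound 4 the estimated value is 4000 nM, with an expected range from 1000 nM to 15000 nM.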

Compound 4, half-maximal inhibitory concentration: 600 nM
Estimate against measurement, compound 4: 6.7-fold (0.82 log units) above; measured number below the stated range.
By their numbers in this assay, from the lowest: compound 1; then compound 2; then compounds 4 and 3 (each within the scatter of the next).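

In this assay, cyano in place of fluoro at this position, ortho to a methoxy group, gives a 1.2-fold lower number from compound 3 to compound 4 (0.08 log units; within the scatter), so the large step seen on the other configuration does not carry over and the size of this change depends on the stereocentre at the saturated ring carbon: the same change on two cores in this assay, a 20-fold higher number (1.30 log units; beyond the scatter) from compound 1 to compound 2 and a 1.2-fold lower number (0.08 log units; within the scatter) from compound 3 to compound 4, 24-fold (1.38 log units) apart, beyond the scatter of two such steps. Changing only that stereocentre with cyano in place gives a 30-fold higher number from compound 2 to compound 4 (1.48 log units; beyond the scatter), so configuration matters with cyano as well as with fluoro: the fact that compounds 2 and 4 differ only in the configuration as drawn. Drawn R, the stereocentre leaves fluoro and cyano within the scatter of each other, whereas drawn S it separates them, and the lowest number of the four belongs to the pairing of S with fluoro, compound 1 at 1 nM.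

The compounds shown carry only fluoro or cyano at this position, so it remains open whether a chloro or a methyl group there would depend on the stereocentre in the same way. Nor do these values say why the swap has so different a size on the two configurations.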